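A Thiophene Swap in a Series Free of Cytotoxicity

This account rests on a few compounds, and the source may have more. Where it says the series, first, only, none or still open, it means among the compounds named here.

Measured compounds:
Compound 1 `Cc1cccc(Cn2ccc3nc(-c4ccccc4)nc-3c2)c1`: in an ADME assay on MDBK cells (Bos taurus) for cytotoxicity (a higher number here means that more compound is tolerated, a lower number that less compound is tolerated), compound 1 reaches only the assay limit, > 100000 nM.
Compound 2 `Brc1ccccc1Cn1ccc2nc(-c3ccccc3)nc-2c1`: compound 2 likewise reaches only the assay limit, > 100000 nM.
Compound 3 `CC(C)CCn1ccc2nc(-c3ccccc3)nc-2c1`: compound 3 also stops at the assay limit, > 100000 nM.

Compound 3 thus stands at the ceiling of this assay, in the same place as the two other compounds, and all three values sit at that limit (the limit of > 100000 nM in this assay, at which 3 of the 3 values shown sit). The measured steps, a step that the two limits leave unreadable from compound 1 to compound 2, a step that the two limits leave unreadable from compound 1 to compound 3 and a step that the two limits leave unreadable from compound 2 to compound 3, cannot be read in size or direction, since both ends of each are limits. The change to compound 4 `Clc1ccc(Cn2ccc3nc(-c4ccccc4)nc-3c2)s1` is 5-chlorothiophen-2-yl in place of isobutyl on a saturated chain carbon bound to an aromatic nitrogen. The three measured steps bear on it only in that every swap of the group on this carbon left the limit untouched; none gives a readable size, so no step beyond the scatter is expected. Compound 4 is therefore expected to sit again at the limit, around 100000 nM (40000 nM to 300000 nM). The expected step of a number no higher from compound 3 to compound 4 (the limit leaves the size open) is estimated as none beyond the scatter.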

Compound 4, half-maximal cytotoxic concentration: > 100000 nM
Compound 4: no number, only a limit (the forecaster's own chance of this, stated with the estimate: 85%); the middle value sits exactly at the limit.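

Compound 4 joins compound 1, compound 2 and compound 3 at the ceiling of this assay, so no step among these four compounds can be read in size or direction: the limit of > 100000 nM in this assay, at which 4 of the 4 values shown sit.

The compounds shown leave open how much of each compound the cells would tolerate past this limit, and whether any group on this carbon changes that.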